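Indole in Place of Ethoxyphenyl: Cytotoxicity Expectation

The source may report more compounds than this note shows. Statements on the series, on what has been measured and on what is new or still open speak of the compounds shown alone.

Compound 2 `CCOc1cccc(-c2ccc(C(=O)N(Cc3cccc(OCCCCCC(=O)O)c3)C(C)C)cc2)c1` has been tested in an ADME assay on BJ cells (Homo sapiens) for cytotoxicity, read by CellTiter-Glo and resazurin assay, with a stated time of 72 h; on this read-out higher numbers stand for an effect only at larger amounts of compound and lower numbers for an effect already at smaller amounts. In this assay compound 2 gives only the limit > 20800 nM. Its closest measured neighbour, compound 1 `CC(C)Oc1cccc(-c2ccc(C(=O)N(Cc3cccc(OCCCCCC(=O)O)c3)C(C)C)cc2)c1`, also gives only the limit > 26000 nM. The step that the two limits leave unreadable from compound 1 to compound 2 therefore has no readable size, as both values sit at the limits the limit of > 26000 nM in this assay, at which 1 of the 2 values shown sits, and (the limit of > 20800 nM in this assay, at which 1 of the 2 values shown sits).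

Compound 3 `CC(C)N(Cc1cccc(OCCCCCC(=O)O)c1)C(=O)c1ccc(-c2ccc3cc[nH]c3c2)cc1` differs from compound 2 by 1H-indol-6-yl in place of 3-ethoxyphenyl on an aromatic carbon. Going by the values given here, no measured step bears directly on this change, and the one known step gives no size. Compound 3 is thus expected to remain without a measurable effect, estimated at 25000 nM with a range from 8000 nM to 80000 nM, a step that the limit leaves unreadable from compound 2 to compound 3 in this assay.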

Compound 3, half-maximal effective concentration: > 26000 nM
Compound 3 was reported as a limit; the forecaster's own chance of this, stated with the estimate: 75%; at least 1.0-fold (0.01 log units) between middle value and limit.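

Going by these compounds alone, all three values for compound 1, compound 2 and compound 3 are limits, not numbers, so no step among them can be read. The compounds shown leave open whether 1H-indol-6-yl and 3-ethoxyphenyl differ in cytotoxicity at all.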